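Pyridin-4-yl for furan-3-yl on the shared core

The compounds below may be only part of what the source reports. "The series", "measured", "known", "first", "only" and "open" are said of these compounds alone.

Working notes on a small set of anilines carrying a nitrile-bearing aryl group on nitrogen. The only numeric result in a functional assay on VCaP cells (Homo sapiens) for antiproliferative activity, read by CCK-8 assay, with a stated time of 6 days (a higher number here means a weaker inhibitor, a lower number a stronger inhibitor), belongs to compound 1 `CCN(c1ccc(C#N)c(Cl)c1)c1cc(-c2ccoc2)ccc1C`, which gives 4010 nM. Compound 2 `CCN(c1ccc(C#N)c(C(F)(F)F)c1)c1cc(-n2ccnc2)ccc1C` reaches only a limit of the assay in this assay, reported as >= 3920 nM; this is the limit of >= 3920 nM in this assay, at which 1 of the 3 values shown sits. Compound 3 `Cc1noc(C)c1-c1cccc2c1CCCN2c1ccc(C#N)c(C(F)(F)F)c1` likewise returns only a limit in this assay, given as > 30000 nM, which is the limit of > 30000 nM in this assay, at which 1 of the 3 values shown sits. Among the measured compounds shown here, no two measured compounds differ in a single place, so no measured step can be drawn from these three results, and compound 1 stands as the sole fixed point.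

The next compound, compound 4 `CCN(c1ccc(C#N)c(Cl)c1)c1cc(-c2ccncc2)ccc1C`, is built from compound 1 by a single change: pyridin-4-yl in place of furan-3-yl on an aromatic carbon. Both groups carry one hydrogen-bond acceptor and no donor, and the count of heavy atoms rises by one. For the measured compounds named here, with no comparable step in the data, the expectation is a change of modest size, most likely within the usual scatter of this assay, with no firm direction. The step of a 1.1-fold lower number from compound 1 to compound 4 (0.06 log units; within the scatter) is therefore expected to be small. Compound 4 is estimated at 3500 nM, within a range of 1200 nM to 10000 nM.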

Compound 4, half-maximal inhibitory concentration: 2900 nM
Estimate against measurement, compound 4: 1.2-fold (0.08 log units) above; measured number inside the range.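

Among the compounds shown here, the first single-place comparison comes from this change, and in this assay it reads a 1.4-fold lower number from compound 1 to compound 4 (0.14 log units; within the scatter), so the exchange of pyridin-4-yl for furan-3-yl does not separate the two compounds at this position. On an aromatic carbon meta to a large group and para to a methyl group, a five-membered aromatic ring and a six-membered aromatic ring, each with 1 hetero atom and 1 hydrogen-bond acceptor, therefore give results that cannot be told apart in this read-out, and this single pair sets no order between them. The data on hand contain nothing that bears on this step, and the two assay limits recorded belong to other compounds.

On these data alone, what stays open is how this position responds to a group of a different kind, such as a morpholine, a primary amine or a carboxylic acid, where the aromatic ring is given up altogether. Also open, as far as these compounds go, is whether pyridin-4-yl in place of furan-3-yl reads the same when the chlorine of the nitrile-bearing aryl group is replaced by trifluoromethyl.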